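The source may report more compounds than this note shows. Statements on the series, on what has been measured and on what is new or still open speak of the compounds shown alone.

In a functional assay on HCT-116 cells (Homo sapiens) for inhibition, read by CCK-8 assay, with a stated time of 72 h, tested at 2 uM (on this read-out lower numbers stand for less inhibition of growth and higher numbers for more inhibition of growth at the one concentration tested), two compounds sharing one core have been measured. Compound 1 (`Nc1ccccc1NC(=O)/C=C/c1ccc(CSc2ccc(F)cc2)cc1`) gives 14.1%, and compound 2 (`Nc1ccccc1NC(=O)/C=C/c1ccc(CSCCc2ccccc2)cc1`) gives 18%. These two numbers cannot be told apart, so compound 2 stands level with compound 1. Compound 3 (`CC(C)(C)c1ccc(SCc2ccc(/C=C/C(=O)Nc3ccccc3N)cc2)cc1`) has not yet been measured in this assay. Its structure differs from that of compound 2 as follows: 4-(tert-butyl)phenyl in place of phenethyl on a sulfur.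

Within the data shown here, only one measured step bears on this change: a number 3.9 percentage points higher from compound 1 to compound 2 (within the scatter). It involves the same sulfur, with phenethyl in place of 4-fluorophenyl. Exchanging these two groups there therefore produced no shift that could be distinguished from the scatter. Among the measured compounds shown here, no measured compound carries 4-(tert-butyl)phenyl, so the data leave the effect of that group open, and the expected range must stay wide. The expectation is therefore for no step beyond the scatter, in either direction. The estimated step is a number 1 percentage points lower from compound 2 to compound 3 (within the scatter). For compound 3, the estimated value is 17%, with an expected range from 6% to 33%.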

Compound 3, percent growth inhibition at one concentration: 6.66%
Beside the measured number, compound 3's estimate is 10.3 percentage points above it; the range from low to high includes it.
By their numbers in this assay, from the lowest: compounds 3, 1 and 2 (each within the scatter of the next, the first and the last beyond it).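

In this assay, the group on this sulfur can now be seen to matter: 4-(tert-butyl)phenyl in place of phenethyl gives a number 11.3 percentage points lower from compound 2 to compound 3 (beyond the scatter), a modest step, whereas the earlier exchange at the same sulfur gave a number 3.9 percentage points higher from compound 1 to compound 2 (within the scatter). Tert-butyl in place of fluoro on an aromatic carbon gives a number 7.4 percentage points lower from compound 1 to compound 3 (within the scatter), so compound 1 and compound 3 cannot be told apart, and compound 2 and compound 3 form the only pair separated beyond the scatter. No measurement at hand accounts for this step.

From the compounds shown here alone, whether a phenyl group carrying an amine or a carboxylic acid in place of the tert-butyl would move the growth inhibition beyond the scatter remains open. Going by these compounds, it is also open whether an unsubstituted phenyl or a benzyl group on the same sulfur, or a chain longer than phenethyl, would stand level with compound 2 or with compound 3.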